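Moving the Carboxylic Acid Around the Outer Ring

The source may hold more compounds than are shown below. What is called first, only, known or untested is meant among the compounds shown, and "the series" means these compounds.

Compound 1 `Cc1ccccc1-n1nc(C)c2c1NC(=O)[C@H](C)S[C@@H]2c1ccc(-c2cccc(C(=O)O)c2)cc1` carries a 3-carboxyphenyl group on the outer ring of its shared core. In an assay on isolated protein for agonist activity at Bile acid receptor (Homo sapiens), read by AlphaScreen, with a stated time of 30 min (a higher number here means that more compound is needed for the effect, a lower number that less compound is needed), compound 1 is recorded as "not active" (no number reported), so no single number places it on the scale. A related compound 2 `Cc1nn(-c2ccccc2F)c2c1C(c1ccc(Oc3ccccc3)cc1)SC(C)C(=O)N2`, which has a phenoxy group in that position instead of an acid, gives 3900 nM in this assay, which shows that this core can reach a measurable response.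

Compound 3 `Cc1ccccc1-n1nc(C)c2c1NC(=O)[C@H](C)S[C@@H]2c1ccc(-c2ccc(C(=O)O)cc2)cc1` keeps everything else and differs from compound 1 only in the outer ring: 4-carboxyphenyl in place of 3-carboxyphenyl on an aromatic carbon. With compound 1 showing no number, the size of this step cannot be computed; any response from compound 3 would itself be a gain beyond the scatter, and a repeat of inactivity is also possible. Compound 3 is expected to give about 6000 nM in this assay, with a range from 1000 nM to 40000 nM.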

Compound 3, half-maximal effective concentration: "not active" (no number reported)
Nothing numeric was reported for compound 3; there is nothing to compare the estimate with.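

Within the data shown here, compound 1 and compound 3 both read as not active in this assay, so no step between them can be read. No measured evidence bears on this result. The compounds shown leave open whether any acid-bearing outer ring on this core can give a measurable response.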